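The compounds below may be only part of what the source reports. "The series", "measured", "known", "first", "only" and "open" are said of these compounds alone.

Measured to date:
- compound 1, `Cn1c(=O)c(C(=O)NCCN)c(O)c2ccccc21`: 67%
- compound 2, `Cn1c(=O)c(C(=O)NCCCCCCN)c(O)c2ccccc21`: 68.5%

In a functional assay on the whole organism (strain Fischer 344) for inhibition, with Rattus norvegicus as the target, read by paw edema, at a dose of 0.01 mmol/kg by the intraperitoneal route (on this read-out lower numbers stand for less inhibition and higher numbers for more inhibition at the one dose given (going by the name of the read-out)), compound 1 gives 67% and compound 2 gives 68.5%. Compound 2 holds the higher of the two numbers, but the step of a number 1.5 percentage points higher from compound 1 to compound 2 (within the scatter) lies within the scatter, so the two compounds are not told apart by this assay.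

Compound 3, `Cn1c(=O)c(C(=O)Nc2ccccc2N)c(O)c2ccccc21`, has not been measured. It differs from compound 2 as follows:

2-aminophenyl in place of 6-aminohexyl on an amide-type nitrogen

Going by the values given here, only one measured step exists, and it concerns a change of chain length on the same amide-type nitrogen: a number 1.5 percentage points higher from compound 1 to compound 2 (within the scatter), which was within the scatter. Among the compounds with values here, no measured step replaces a saturated chain by an aromatic ring at this place, so the step to compound 3 rests on no direct precedent. Within the data shown here, the single known step shows the number in this assay staying level across a change of the group on the amide-type nitrogen, without a move beyond the scatter, and the same is taken as the working expectation here, with a wider range to cover the lack of a directly comparable step.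

Compound 3 is therefore expected to give about 62% in this assay, with a range from 40% to 80%. The expected step of a number 6.5 percentage points lower from compound 2 to compound 3 (within the scatter) is estimated to lie within the scatter.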

Compound 3, a percentage reported as inhibition, in the whole organism at one dose (the size of the read-out at that dose, not a potency): 85.3%
For compound 3 the middle estimate is 23.3 percentage points below the measured one; the whole stated range lies below it.
By their numbers in this assay, from the lowest: compounds 1 and 2 (each within the scatter of the next); then compound 3.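

In this assay, the amide-type nitrogen proves sensitive to the kind of group it carries: 2-aminophenyl in place of 6-aminohexyl gives a number 16.8 percentage points higher from compound 2 to compound 3 (beyond the scatter), and 2-aminophenyl in place of 2-aminoethyl gives a number 18.3 percentage points higher from compound 1 to compound 3 (beyond the scatter), whereas the change between the two open chains gave only a number 1.5 percentage points higher from compound 1 to compound 2 (within the scatter). The groups exchanged in the first of these steps match in heavy atoms, hydrogen-bond donors, hydrogen-bond acceptors and net charge, so the step goes with one six-membered aromatic ring of carbon taking the place of an open chain, not with any difference in those counts. Nothing available bears on what lies behind this step.

Still open, as far as these compounds go, is which part of 2-aminophenyl carries the step: a plain phenyl group would test the need for the amine, and a 2-aminocyclohexyl group would test the need for an aromatic ring. From the compounds shown here alone, the read-out also stands at a single dose, so the order of the compounds at other doses remains unknown.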